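The source may report more compounds than this note shows. Statements on the series, on what has been measured and on what is new or still open speak of the compounds shown alone.

Going by the values given here, compound 1 `CCCOc1c(C(=O)N(C)Cc2cc(C(F)(F)F)cc(C(F)(F)F)c2)c(=O)n(C)c2ccccc12` sits at the higher end of the two numbers measured so far: in an assay on cells for inhibition of phosphatidylcholine:ceramide cholinephosphotransferase 2 (Homo sapiens), read by mass spectrometry, with stated times of 60 min and 30 min (on this read-out lower numbers stand for stronger inhibition and higher numbers for weaker inhibition), compound 1 gives 2100 nM, while compound 2 `CCOc1cc(CN(C)C(=O)c2c(OCCCC3CCN(C(=O)OC(C)(C)C)CC3)c3ccccc3n(C)c2=O)cc(OCC)c1` gives 380 nM in this assay, a gap that lies beyond the usual scatter. Compound 3 `CN(Cc1cc(C(F)(F)F)cc(C(F)(F)F)c1)C(=O)c1c(OCCCC(F)(F)F)c2ccccc2n(C)c1=O` departs from compound 1 by a single change, (trifluoromethyl in place of hydrogen on a saturated chain carbon, three bonds along the chain from an oxygen on an aromatic ring). Among the compounds with values here, no measured pair shows this exact change, so the expected step is a modest one toward a lower number. The step expected is a 1.8-fold lower number from compound 1 to compound 3 (0.24 log units; within the scatter). Compound 3 is therefore estimated at 1200 nM, with a range from 400 nM to 3500 nM.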

Compound 3, half-maximal inhibitory concentration: 120 nM
Beside the measured number, compound 3's estimate is 10-fold (1.00 log units) above it; the whole stated range lies above it.
By their numbers in this assay, from the lowest: compound 3; then compound 2; then compound 1.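

Placing trifluoromethyl in place of hydrogen on a saturated chain carbon, three bonds along the chain from an oxygen on an aromatic ring, gives an 18-fold lower number from compound 1 to compound 3 (1.24 log units; beyond the scatter). This shows that the position responds strongly to this change, which turns propyl into 4,4,4-trifluorobutyl while the rest of compound 1 stays the same. Nothing shown here accounts for the size of the step. The compounds leave open whether a plain butyl chain, a longer chain or an amine at this position would give a comparable step.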